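The source may report more compounds than this note shows. Statements on the series, on what has been measured and on what is new or still open speak of the compounds shown alone.

compound 1 `CCNc1nc(Cl)nc(N[C@@H](C)c2ccccc2)n1` gives 17.4 nM
compound 2 `CCNc1nc(Cl)nc(NC(C)c2ccccc2)n1` gives 43.7 nM

In an ADME assay on the whole organism for inhibition, with Echinochloa crus-galli var. formosensis as the target (a lower number here means a stronger inhibitor, a higher number a weaker inhibitor), compound 1 has the lower number of the two. Compound 3 `CCN(CC)c1nc(Cl)nc(N[C@@H](C)c2ccccc2)n1` differs from it by ethyl in place of hydrogen on a nitrogen on an aromatic ring (ethylamino to diethylamino). Going by the values given here, the only measured step, a 2.5-fold higher number from compound 1 to compound 2 (0.40 log units; beyond the scatter), concerns the stereocentre alone (the fact that one of compounds 1 and 2 is drawn with a defined configuration and the other without, at the place where they differ) and leaves that nitrogen untouched, so it gives no direct measure of this change. A higher number is tentatively expected, with the size poorly constrained. The expected step is an 11-fold higher number from compound 1 to compound 3 (1.06 log units; beyond the scatter) and is larger than the measured one. For compound 3 the estimated value is 200 nM (range 35 nM to 1200 nM).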

Compound 3, half-maximal inhibitory concentration: 19100 nM
For compound 3 the middle estimate is 96-fold (1.98 log units) below the measured one, outside the stated range (above it).
By their numbers in this assay, from the lowest: compound 1; then compound 2; then compound 3.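

In this assay, this nitrogen on an aromatic ring proves highly sensitive to substitution: ethyl in place of hydrogen, ethylamino to diethylamino, gives the largest step in the series (a 1100-fold higher number from compound 1 to compound 3 (3.04 log units; beyond the scatter)). That step far exceeds the one at the stereocentre (a 2.5-fold higher number from compound 1 to compound 2 (0.40 log units; beyond the scatter)), so the hydrogen-bearing ethylamino form is the better of the two at this position, with the stereocentre held the same.

Still open, from the compounds shown here alone, is whether a methylamino, a dimethylamino or a longer chain such as propylamino at this nitrogen would stay close to compound 1. Nothing shown here accounts for the size of the step from ethylamino to diethylamino.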